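Sulfonamide series: trifluoromethyl to methanesulfonamido step

The compounds below may be only part of what the source reports. "The series", "measured", "known", "first", "only" and "open" are said of these compounds alone.

Measured so far:
Compound 1, `CCCCc1cn(-c2cccc(S(=O)(=O)Nc3ccccc3C(F)(F)F)c2)nn1`, in an assay for inhibition of ATP-dependent RNA helicase DDX3X (Homo sapiens), read by FRET, with a stated time of 40 min, in the presence of a further agent that is not named here (on this read-out lower numbers stand for stronger inhibition and higher numbers for weaker inhibition), gives 400 nM.
Compound 2, `CCOCc1cn(-c2cccc(S(=O)(=O)Nc3ccccc3C(F)(F)F)c2)nn1`, in this assay gives 400 nM.
Compound 3, `CCOCc1cn(-c2cccc(S(=O)(=O)Nc3cccc(C(=O)O)c3)c2)nn1`, in this assay gives "not determined" (no result reported).

Compound 2 stands level with compound 1 on the numbers shown; the only step with two numbers, no change at the digits printed from compound 1 to compound 2 (within the scatter), lies within the scatter and concerns the ethoxy in place of propyl on a saturated chain carbon bound to an aromatic carbon. Compound 3 carries no result, so nothing can be said of it beyond its structure.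

Compound 4, `CCOCc1cn(-c2cccc(S(=O)(=O)Nc3ccccc3NS(C)(=O)=O)c2)nn1`, differs from compound 2 in one place: methanesulfonamido in place of trifluoromethyl on an aromatic carbon. Within the data shown here, no measured step touches this part of the molecule; the one step on record sits on the chain at the other side of the shared core and was flat. Among the measured compounds shown here, there is thus no measured basis for a direction, and the change is larger in kind than the one step seen. The expectation is a step of a 2.0-fold higher number from compound 2 to compound 4 (0.30 log units; within the scatter) of modest size, with a wide range to either side. Compound 4 is estimated at 800 nM in this assay, between 200 nM and 3500 nM.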

Compound 4, half-maximal inhibitory concentration: 80 nM
Estimate against measurement, compound 4: 10-fold (1.00 log units) above, and the stated range ends above it.
By their numbers in this assay, from the lowest: compound 4; then compounds 1 and 2 (each within the scatter of the next).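

In this assay, among these compounds, methanesulfonamido in place of trifluoromethyl on this aromatic carbon gives a 5.0-fold lower number from compound 2 to compound 4 (0.70 log units; beyond the scatter), so this position responds to substitution in a way the only earlier step, no change at the digits printed from compound 1 to compound 2 (within the scatter), on the saturated chain, did not show. The step exchanges a group with no hydrogen-bond donors or acceptors for one that has both, and it also brings in a sulfur, a nitrogen and two oxygens, so several features change at once and this single pair cannot separate them. No measurement at hand accounts for the lower number, and the feature of methanesulfonamido that matters remains unassigned.

On these data alone, it remains open whether a plain amine, an acetamido group or a longer ethanesulfonamido group on this aromatic carbon would keep the lower number of compound 4, which would help show whether the sulfonyl part or the amide hydrogen carries the step. Among the compounds shown here, it is also open whether the chain exchange stays flat with methanesulfonamido in place, since the one chain step on record was read with trifluoromethyl on the ring.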